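Trifluoromethyl to ethynyl: a step seen only through limits

The source may hold more compounds than are shown below. What is called first, only, known or untested is meant among the compounds shown, and "the series" means these compounds.

Compound 1 `COc1cccc(-c2nc3c(c(C)nn3-c3ccccc3)c(-c3ccccc3O)c2C#N)c1`: > 23000 nM
Compound 2 `CCc1ccc(-c2nc3c(c(C)nn3-c3ccccc3)c(-c3ccccc3C#N)c2C#N)cc1`: > 20000 nM
Compound 3 `CCc1ccc(-c2nc3c(c(C)nn3-c3ccccc3)c(-c3ccccc3C(F)(F)F)c2C#N)cc1`: > 20000 nM

All three entries come from an ADME assay on BJ cells (Homo sapiens) for cytotoxicity, with a stated time of 72 h (on this read-out lower numbers stand for an effect already at smaller amounts and higher numbers for an effect only at larger amounts of compound), and each is a limit, not a number. The series holds (the limit of > 20000 nM in this assay, at which 2 of the 3 values shown sit), and also (the limit of > 23000 nM in this assay, at which 1 of the 3 values shown sits). Compound 3 stands at such a limit, > 20000 nM, and this is where the expectation starts.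

Compound 4 `C#Cc1ccccc1-c1c(C#N)c(-c2ccc(CC)cc2)nc2c1c(C)nn2-c1ccccc1` differs from compound 3 at one place, on an aromatic carbon ortho to a large group, with ethynyl in place of trifluoromethyl (ethynyl in place of trifluoromethyl on an aromatic carbon). The closest measured change is a step that the two limits leave unreadable from compound 2 to compound 3, where trifluoromethyl takes the place of cyano on an aromatic carbon. That change offers no size to carry over, and no measured number shows a change at this carbon moving the read-out. No step beyond the usual scatter is therefore expected, and no direction is favoured. The expected change is a number no higher from compound 3 to compound 4 (the limit leaves the size open). Compound 4 is estimated at 20000 nM, with an expected range from 9000 nM to 40000 nM, and it may well be reported as a limit again.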

Compound 4, half-maximal effective concentration: > 20000 nM
Compound 4: a limit, no number (the forecaster's own chance of this, stated with the estimate: 80%); the middle value sits exactly at the limit.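

Compound 2, compound 3 and compound 4 are all reported only as limits, not numbers, so the steps among them cannot be read. The compounds shown leave open what actual number any of them would give, and whether changing the group on this aromatic carbon moves the read-out at all.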